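This account rests on a few compounds, and the source may have more. Where it says the series, first, only, none or still open, it means among the compounds named here.

Measured in a functional assay on SK-MEL cells (Homo sapiens) for cytotoxicity, read by MTT assay, with a stated time of 6 days; a higher number here means that more compound is needed for the effect, a lower number that less compound is needed:
- Compound 1 `O=c1cc(-c2ccc([N+](=O)[O-])cc2)oc2ccc(O)cc12`: 21 ug/mL
- Compound 2 `O=c1cc(-c2ccc([N+](=O)[O-])cc2)oc2cc(O)ccc12`: > 25 ug/mL, a limit of the assay and not a number
- Compound 3 `COc1cc(-c2cc(=O)c3cc(O)ccc3o2)cc(OC)c1OC`: 5.87 ug/mL

Compound 3 has the lower of the two actual numbers, and its gap to compound 1 lies beyond the usual scatter. Less of compound 3 is therefore needed for the effect in this assay.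

Compound 4 `COc1cc(-c2cc(=O)c3cc(O)ccc3o2)cc(OC)c1O[Si](C)(C)C(C)(C)C` has not been measured yet. It keeps the core of compound 3 with one change: a group of 7 heavy atoms (6 carbon, 1 silicon; no ring) in place of one carbon atom, on an oxygen on an aromatic ring. A group of 7 heavy atoms takes the place of one carbon atom, on an oxygen on an aromatic ring.

Within the data shown here, no measured pair shows a change of this kind, so the guide is weak. The starting point is compound 3 at 5.87 ug/mL, and the expectation is a modest upward move, an estimated 1.7-fold higher number from compound 3 to compound 4 (0.23 log units; within the scatter). Also in view is the limit of > 25 ug/mL in this assay, at which 1 of the 3 values shown sits, so a limit instead of a number is possible here too. The expected value for compound 4 is 10 ug/mL, with an estimated range of 3.5 ug/mL to 25 ug/mL.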

Compound 4, concentration for half-maximal effect: 2.95 ug/mL
Compound 4: the middle estimate sits 3.4-fold (0.53 log units) above what was measured; measured number below the stated range.
By their numbers in this assay, from the lowest: compounds 4 and 3 (each within the scatter of the next); then compound 1. At a limit, above all of these: compound 2.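

In this assay, among these compounds, this is the first look at a change on this oxygen on an aromatic ring, and replacing the methyl with a group of 7 heavy atoms gives a 2.0-fold lower number from compound 3 to compound 4 (0.30 log units; within the scatter). At this place, then, the group can grow from one carbon atom to that size while compound 4 stays indistinguishable from compound 3 in this assay. Compound 2 remains the only compound at a limit, which is not a number, and compound 4 does not join it: the limit of > 25 ug/mL in this assay, at which 1 of the 4 values shown sits.

A single step at a single place cannot show how the number responds to the size or the make-up of the group here, and nothing in it separates the role of the silicon from that of the carbon atoms. A longer carbon chain or an amine at this place would test the same position with a different kind of group.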